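Para-substituent on the benzyl group: bromo at compound 4

The source may hold more compounds than are shown below. What is called first, only, known or untested is meant among the compounds shown, and "the series" means these compounds.

Three compounds of the series share one core and differ only in the group on the benzyl ring. Compound 1 `CCCSc1nc(N/N=C(\C)c2ccccc2O)c2nnn(Cc3ccc(Cl)cc3)c2n1` carries chloro there and gives 42600 nM in a functional assay on MCF7 cells (Homo sapiens) for antiproliferative activity, read by MTT assay, with a stated time of 72 h; on this read-out lower numbers stand for stronger inhibition and higher numbers for weaker inhibition. Compound 2 `CCCSc1nc(N/N=C(\C)c2ccccc2O)c2nnn(Cc3ccc(O)cc3)c2n1` carries hydroxy and gives 9520 nM. Compound 3 `CCCSc1nc(N/N=C(\C)c2ccccc2O)c2nnn(Cc3ccccc3)c2n1` carries hydrogen and gives 11000 nM. On these numbers compound 3 stands second highest of the three: its nearest neighbour is compound 2, a 1.2-fold higher number from compound 2 to compound 3 (0.06 log units; within the scatter), and its furthest is compound 1, a 3.9-fold lower number from compound 1 to compound 3 (0.59 log units; beyond the scatter).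

Compound 4 `CCCSc1nc(N/N=C(\C)c2ccccc2O)c2nnn(Cc3ccc(Br)cc3)c2n1` is not yet measured. It differs from compound 3 by bromo in place of hydrogen on an aromatic carbon. The step that bears on this change is the one with chloro at the same place, which read a 3.9-fold lower number from compound 1 to compound 3 (0.59 log units; beyond the scatter); the other two steps, a 4.5-fold lower number from compound 1 to compound 2 (0.65 log units; beyond the scatter) and a 1.2-fold higher number from compound 2 to compound 3 (0.06 log units; within the scatter), concern hydroxy and hydrogen and give no direct guidance for bromo. With chloro having given the highest number of the three, a higher number than compound 3 is expected for compound 4, of a size comparable to the chloro step, a 2.7-fold higher number from compound 3 to compound 4 (0.44 log units; beyond the scatter). For compound 4 the expected value in this assay is 30000 nM, with a range from 12000 nM to 80000 nM.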

Compound 4, half-maximal inhibitory concentration: 15600 nM
Beside the measured number, compound 4's estimate is 1.9-fold (0.28 log units) above it, and the stated range covers the measured number.
By their numbers in this assay, from the lowest: compounds 2, 3 and 4 (each within the scatter of the next); then compound 1.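

In this assay the two halogens at this place do not read alike: a 2.7-fold lower number from compound 1 to compound 4 (0.44 log units; beyond the scatter), so the high number of compound 1 does not carry over when bromo replaces chloro. Bromo also stays level with the other two groups, since a 1.4-fold higher number from compound 3 to compound 4 (0.15 log units; within the scatter) for bromo in place of hydrogen and a 1.6-fold higher number from compound 2 to compound 4 (0.21 log units; within the scatter) for bromo in place of hydroxy, which places compound 2, compound 3 and compound 4 together with compound 1 alone apart from them. A halogen on the benzyl ring therefore does not by itself go with a higher number on this read-out: compound 1 fits such a pattern, and compound 4 goes against it.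

On these data alone, whether chloro is a lone outlier stays open, and a fluoro, methoxy, amino or carboxylic acid group at the same place, or a longer chain in place of the benzyl group, would test how far this flat reading extends. Nothing available here bears on why chloro and bromo part in this assay.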